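The compounds below may be only part of what the source reports. "The series", "measured", "known", "first", "only" and "open" are said of these compounds alone.

For the measured compounds named here, compound 1 `Cc1ccc(C2(CNC(=O)Nc3c(C(C)C)cccc3C(C)C)CCCC2)cc1` gives 25 nM in an assay on microsomes for inhibition of acyl-CoA:cholesterol acyltransferase (Oryctolagus cuniculus) (a higher number here means a weaker inhibitor, a lower number a stronger inhibitor), the lowest of the two numbers so far, with compound 2 `CC(C)c1ccc(C2(CNC(=O)Nc3c(C(C)C)cccc3C(C)C)CCCC2)cc1` at 48 nM its nearest; the only measured step, a 1.9-fold higher number from compound 1 to compound 2 (0.28 log units; within the scatter), lies within the scatter. Compound 3 `CC(C)c1cccc(C(C)C)c1NC(=O)NCC1(c2ccc(C(=O)O)cc2)CCCC1` differs from compound 1 by carboxy in place of methyl on an aromatic carbon. Going by the values given here, no measured step covers a carboxy group entering the series; the single known step exchanges one alkyl group for another and bears only loosely on this change. A higher number is expected for compound 3, with wide uncertainty, as a 12-fold higher number from compound 1 to compound 3 (1.08 log units; beyond the scatter). Compound 3 is estimated at 300 nM, in a range from 50 nM to 3000 nM.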

Compound 3, half-maximal inhibitory concentration: 3100 nM
Compound 3: the middle estimate sits 10-fold (1.01 log units) below what was measured; the measured number lies above the stated range.
By their numbers in this assay, from the lowest: compounds 1 and 2 (each within the scatter of the next); then compound 3.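

This position, para to a large group, is not indifferent to the group placed on it: the two alkyl groups lie within the scatter of each other, but carboxy brings a 120-fold higher number from compound 1 to compound 3 (2.09 log units; beyond the scatter) and a 65-fold higher number from compound 2 to compound 3 (1.81 log units; beyond the scatter). Both steps are large, so the 4-methylphenyl to 4-carboxyphenyl change marks the first clear sensitivity in the series. Nothing at hand bears on what lies behind this rise.

Still open, from the compounds shown here alone, is whether the rise belongs to the carboxylic acid itself or extends to a methyl ester, a primary amide or a hydroxymethyl group at this position. A carboxylic acid elsewhere on the core of compound 1 remains a separate question.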